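Swapping the Ring on the Carbonyl Carbon of Compound 2

A few compounds are considered here, and "the series" means these few. Any claim that something is new, unique, unknown or untested is made for them only; others in the source may bear on it.

Measured so far:
- Compound 1 `CCCCCCCCC(O)C/C=C/CCC(=O)N(C)C/C(=C\Cl)C/C(=C\C(=O)N1CC(OC)=CC1=O)OC` gives 2900 nM
- Compound 2 `CCCCCCCC[C@@H](C/C=C/CCC(=O)N(C)C/C(=C\Cl)C/C(=C\C(=O)N1CC(OC)=CC1=O)OC)OC` gives 2900 nM

In a functional assay on L1210 cells (Mus musculus) for inhibition (a higher number here means a weaker inhibitor, a lower number a stronger inhibitor), compound 2 reads 2900 nM, level with the only other measured compound at the digits shown.

The next candidate is compound 3 `CCCCCCCC[C@@H](C/C=C/CCC(=O)N(C)C/C(=C\Cl)C/C(=C\C(=O)N1C[C@H](O)CC1=O)OC)OC`. It keeps the long chain of compound 2 and alters the group on a carbonyl carbon: a group of 7 heavy atoms (4 carbon, 1 nitrogen, 2 oxygen; one five-membered non-aromatic ring with 1 hetero atom) in place of a group of 8 heavy atoms (5 carbon, 1 nitrogen, 2 oxygen; one five-membered non-aromatic ring with 1 hetero atom), on a carbonyl carbon. The entering group is 4-hydroxy-2-oxopyrrolidin-1-yl.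

Within the data shown here, only one measured step exists. In it, no change at the digits printed from compound 1 to compound 2 (within the scatter), the change lies on a saturated chain carbon bound to a double-bonded chain carbon, not on the carbonyl carbon. Among the measured compounds shown here, that step therefore says little about the new change, and no measured compound shows what a change at this place does. The data give no firm direction, so a wide range is the honest choice in this assay.

The expected change, leaning only slightly towards weaker inhibition, is a 1.2-fold higher number from compound 2 to compound 3 (0.08 log units; within the scatter). For compound 3 the estimated value is 3500 nM, with an expected range from 1000 nM to 12000 nM.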

Compound 3, half-maximal inhibitory concentration: 2900 nM
The estimate for compound 3 lay 1.2-fold (0.08 log units) above the measured number, and the stated range covers the measured number.
By their numbers in this assay, from the lowest: compounds 1, 2 and 3 (each within the scatter of the next).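

Among these compounds, this is the first measured step at the carbonyl carbon whose other neighbour is a double-bonded chain carbon: in this assay, placing 4-hydroxy-2-oxopyrrolidin-1-yl there in place of the ring of compound 2 gives no change at the digits printed from compound 2 to compound 3 (within the scatter). The entering group carries a hydrogen-bond donor where the leaving group has none, has one double bond fewer outside aromatic rings and adds a defined stereocentre, yet this set of differences taken together does not separate the two compounds in this assay. Nothing measured alongside these compounds speaks to why they read alike.

From the compounds shown here alone, this rests on a single pair of compounds, so it remains unknown whether any group at this place can move the number beyond the scatter. Also open, going by these compounds, is how the mirror-image arrangement of the hydroxyl group on the ring would read, or a group of another kind on the carbonyl carbon, such as an open-chain amine or a carboxylic acid.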